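Working notes: amide-nitrogen substituent, compound 1 to compound 3

The compounds below may be only part of what the source reports. "The series", "measured", "known", "first", "only" and "open" are said of these compounds alone.

Among the compounds with values here, compound 1 `CN1C(=O)C(CCO[Si](c2ccccc2)(c2ccccc2)C(C)(C)C)COC12C=CC(=O)C=C2` gives 679 nM in an assay on isolated protein for inhibition of N-lysine methyltransferase SMYD2 (Homo sapiens), read by filter binding, with a stated time of 1 h (a lower number here means a stronger inhibitor, a higher number a weaker inhibitor), and is the only compound with a numeric value here. Compound 2 `CN1C(=O)C(CCO[Si](C)(C)C(C)(C)C)COC12C=CC(=O)C=C2` returns only a limit, > 30000 nM, in this assay. Within the data shown here, the single piece of evidence is the limit of > 30000 nM in this assay, at which 1 of the 2 values shown sits, so compound 1 stands alone as the measured number. Compound 3 `CC(C)N1C(=O)C(CCO[Si](c2ccccc2)(c2ccccc2)C(C)(C)C)COC12C=CC(=O)C=C2` differs by isopropyl in place of methyl on an amide-type nitrogen in a ring. Among the measured compounds shown here, no measured pair covers this change, so only a small step is expected, a 1.3-fold higher number from compound 1 to compound 3 (0.12 log units; within the scatter), not clearly beyond the scatter in either direction. Compound 3 is therefore estimated at 900 nM, with a range from 300 nM to 3000 nM.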

Compound 3, half-maximal inhibitory concentration: 399 nM
Compound 3: the middle estimate sits 2.3-fold (0.35 log units) above what was measured; measured number inside the range.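

Isopropyl in place of methyl on the amide-type nitrogen in a ring gives a 1.7-fold lower number from compound 1 to compound 3 (0.23 log units; within the scatter) in this assay. At this position, a group of 3 heavy atoms can therefore replace one of 1 heavy atom with no change beyond the scatter, so compound 1 and compound 3 cannot be ranked. Nothing measured here bears on a cause for this step.

Still open, from the compounds shown here alone, is whether this nitrogen also accepts a much longer chain, a benzyl group, an amine or a carboxylic acid.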